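Benzoate ester series on A549 cells: dichlorophenyl to nitrophenyl

The source may report more compounds than this note shows. Statements on the series, on what has been measured and on what is new or still open speak of the compounds shown alone.

Three compounds carry numbers in a functional assay on A549 cells (Homo sapiens) for inhibition, read by XTT assay, with a stated time of 48 h; a lower number here means a stronger inhibitor, a higher number a weaker inhibitor. Compound 1 `COc1ccc(C(=O)/C(=C/c2ccc(Cl)cc2Cl)CC(C)OC(C)=O)cc1` gives 40300 nM. Compound 2 `C=C(C(=O)c1ccc(OC)cc1)C(OC(C)=O)c1ccc(Cl)cc1Cl` gives 17600 nM, and compound 3 `C=C(C(=O)c1ccc(OC)cc1)C(OC(=O)c1ccccc1)c1ccc(Cl)cc1Cl` gives 79200 nM. Within the data shown here, compound 3 stands at the highest of the three numbers; its distance to compound 1 lies within the scatter, while the one measured step, a 4.5-fold higher number from compound 2 to compound 3 (0.65 log units; beyond the scatter), lies beyond it.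

Compound 4 `C=C(C(=O)c1ccc(OC)cc1)C(OC(=O)c1ccccc1)c1ccccc1[N+](=O)[O-]` differs from compound 3 in one place: 2-nitrophenyl in place of 2,4-dichlorophenyl on a saturated chain carbon bound to a double-bonded chain carbon and an oxygen next to a carbonyl group. The enters group carries one double bond outside aromatic rings and two hydrogen-bond acceptors, where the leaves group carries none.

Among the measured compounds shown here, no measured step concerns the aryl group on the saturated chain carbon: the only step known, from compound 2 to compound 3, concerns the ester carbonyl and not this position. It therefore gives no direction for the present change, and the expectation in this assay rests on the value of compound 3 alone, with a broad range on either side. For compound 4 the step of a 1.1-fold lower number from compound 3 to compound 4 (0.05 log units; within the scatter) is expected to be small, within the scatter, with no preferred direction. Compound 4 is estimated at 70000 nM, with a range from 20000 nM to 250000 nM.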

Compound 4, half-maximal inhibitory concentration: 45500 nM
Compound 4: the middle estimate sits 1.5-fold (0.19 log units) above what was measured; the range from low to high includes it.
By their numbers in this assay, from the lowest: compound 2; then compounds 1, 4 and 3 (each within the scatter of the next).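

In this assay, among these compounds, placing 2-nitrophenyl in place of 2,4-dichlorophenyl on a saturated chain carbon bound to a double-bonded chain carbon and an oxygen next to a carbonyl group gives the first measured step at this position (a 1.7-fold lower number from compound 3 to compound 4 (0.24 log units; within the scatter)), and that step lies within the scatter. With the benzoate ester and the rest of the core held fixed, the assay therefore does not separate these two aryl groups, although the 2-nitrophenyl group adds one double bond outside aromatic rings and two hydrogen-bond acceptors; this rests on a single pair of compounds and sets no pattern for the position. No measured evidence bears on this result.

The compounds shown leave open whether other groups at this carbon, such as an unsubstituted phenyl or a 2-aminophenyl, would also stay within the scatter of compound 3 or move beyond it. They also leave open whether 2-nitrophenyl and 2,4-dichlorophenyl would remain inseparable with an acetate ester in place of the benzoate, the change that gave the larger step (a 4.5-fold higher number from compound 2 to compound 3 (0.65 log units; beyond the scatter)).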